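Pyridone glycosides against MCF7: removal of the sugar

A few compounds are considered here, and "the series" means these few. Any claim that something is new, unique, unknown or untested is made for them only; others in the source may bear on it.

Measured so far:
- compound 1, `CC(=O)OC[C@H]1O[C@@H](n2c(-c3ccc(Cl)cc3)cc(-c3ccc(Cl)cc3)c(C#N)c2=O)[C@H](OC(C)=O)[C@@H](OC(C)=O)[C@@H]1OC(C)=O`, 6.3 ug/mL
- compound 2, `N#Cc1c(-c2ccc(Cl)cc2)cc(-c2ccc(Cl)cc2)n([C@@H]2O[C@H](CO)[C@@H](O)[C@H](O)[C@H]2O)c1=O`, 14.2 ug/mL
- compound 3, `N#Cc1c(-c2ccc(Cl)cc2)cc(-c2ccc(Cl)cc2)n([C@@H]2O[C@H](COC(=O)c3ccccc3)[C@@H](OC(=O)c3ccccc3)[C@H]2OC(=O)c2ccccc2)c1=O`, 5.9 ug/mL

Of the compounds shown here, three have been tested in a functional assay on MCF7 cells (Homo sapiens) for cytotoxicity, read by sulforhodamine B assay, with a stated time of 48 h; on this read-out lower numbers stand for stronger inhibition and higher numbers for weaker inhibition. Compound 2 stands at the highest of the three numbers. Its nearest neighbour is compound 1, whose number is lower by a gap beyond the usual scatter; the furthest is compound 3, lower again by a gap beyond the scatter. Compound 1 and compound 3 lie close to each other.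

The next compound, compound 4 with structure `N#Cc1c(-c2ccc(Cl)cc2)cc(-c2ccc(Cl)cc2)[nH]c1=O`, has not been measured in this assay. It differs from compound 2 in one place: hydrogen in place of 3,4,5-trihydroxy-6-(hydroxymethyl)oxan-2-yl on an aromatic nitrogen. Within the data shown here, no step between measured compounds covers this change, so nothing measured points the way directly. The two acylated sugars gave lower numbers than the free sugar, but a compound lacking the sugar altogether is not bracketed by these three. The step from compound 2 to compound 4 is expected to be small and toward a higher number, likely near the edge of the scatter: a 1.4-fold higher number from compound 2 to compound 4 (0.15 log units; within the scatter). Compound 4 is therefore estimated at 20 ug/mL, within a range from 7 ug/mL to 55 ug/mL.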

Compound 4, half-maximal inhibitory concentration: "not active" (no number reported)
No number was reported for compound 4, and the estimate cannot be compared.
By their numbers in this assay, from the lowest: compounds 3 and 1 (each within the scatter of the next); then compound 2.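

Among these compounds, compound 4 is reported as not active, with no number in this assay and so no step from compound 2 can be read. The compounds shown leave open how far compound 4 lies from compound 2 on this read-out. No data given here bear on this result.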